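Cytotoxicity notes on compound 2 and compound 3

This account rests on a few compounds, and the source may have more. Where it says the series, first, only, none or still open, it means among the compounds named here.

Compound 1 `CC(C)(C)c1ccc(N(C(=O)c2ccco2)C(C(=O)NC2CCCCC2)c2cccnc2)cc1` and compound 2 `C[C@H](NC(=O)C(c1cccnc1)N(C(=O)c1ccco1)c1ccc([Si](C)(C)C)cc1)c1ccccc1` have both been run in a toxicity assay on Vero C1008 cells (Chlorocebus sabaeus) for cytotoxicity, read by neutral red uptake, with a stated time of 5 days; on this read-out higher numbers stand for lower toxicity in this test and lower numbers for higher toxicity in this test. In this assay compound 1 gives 18200 nM. In this assay compound 2 gives 19400 nM; against compound 1 the gap is within the scatter, so the two stand together. Compound 3 `C[C@H](NC(=O)C(c1cccnc1)N(C(=O)c1ccco1)c1ccc(-c2ccco2)cc1)c1ccccc1` is unmeasured; it differs from compound 2 by a group of 5 heavy atoms (4 carbon, 1 oxygen; one five-membered aromatic ring with 1 hetero atom) in place of a group of 4 heavy atoms (3 carbon, 1 silicon; no ring), on an aromatic carbon. Among the compounds with values here, no measured step of this kind is available, so the change is expected to move this assay by no more than the scatter, in no set direction. Compound 3 is expected at 17000 nM, range 8000 nM to 40000 nM. The expected step is a 1.1-fold lower number from compound 2 to compound 3 (0.06 log units; within the scatter).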

Compound 3, half-maximal cytotoxic concentration: 56400 nM
Compound 3: the middle estimate sits 3.3-fold (0.52 log units) below what was measured; the whole stated range lies below it.
By their numbers in this assay, from the lowest: compounds 1 and 2 (each within the scatter of the next); then compound 3.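

Replacing the silicon-containing group with furan-2-yl, on an aromatic carbon para to a large group, gives a 2.9-fold higher number from compound 2 to compound 3 (0.46 log units; beyond the scatter) in this assay. This position can therefore shift the read-out beyond the scatter, here toward lower toxicity in this test, though this is a single step and sets no trend. Nothing measured here accounts for the shift.

Going by these compounds, it remains open whether the step follows from furan-2-yl entering or from the silicon-containing group leaving. On these data alone, how an amine, a carboxylic acid or a phenyl ring would read at this position also remains open.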